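Dropping the Para Methyl from a Benzylthio Side Chain

The source may hold more compounds than are shown below. What is called first, only, known or untested is meant among the compounds shown, and "the series" means these compounds.

For the measured compounds named here, compound 3 `C#CCNC1CCc2c(SCc3ccc(C)cc3)cccc21` gives 320 nM in an ADME assay on isolated protein for inhibition of Amine oxidase [flavin-containing] B (Homo sapiens) (on this read-out higher numbers stand for weaker inhibition and lower numbers for stronger inhibition), the lowest of the two numbers measured so far. Its nearest neighbour, compound 2 `C#CCNC1CCc2c(SCc3ccc(C(F)(F)F)cc3)cccc21`, gives 930 nM in this assay. Compound 1 `C#CCNC1CCc2c(SCc3cccc(C)c3)cccc21` sits at a limit of this assay, > 100000 nM, and so contributes no number (the limit of > 100000 nM in this assay, at which 1 of the 3 values shown sits). Compound 4 `C#CCNC1CCc2c(SCc3ccccc3)cccc21` is the next step: hydrogen in place of methyl on an aromatic carbon, leaving only hydrogen para to a large group, so that 4-methylphenyl becomes plain phenyl. Going by the values given here, two measured steps bear on this. The move from 3-methylphenyl to 4-methylphenyl, an at least 310-fold lower number from compound 1 to compound 3 (2.49 log units; beyond the scatter), is large, showing that this ring is sensitive to what it carries. The exchange of trifluoromethyl for methyl at the same aromatic carbon, a 2.9-fold lower number from compound 2 to compound 3 (0.46 log units; beyond the scatter), is modest. Taking the methyl away entirely is expected to raise the number in this assay by a modest amount, comparable to that second step, a 2.5-fold higher number from compound 3 to compound 4 (0.40 log units; beyond the scatter). Compound 4 is therefore estimated at 800 nM, within a range from 250 nM to 3000 nM.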

Compound 4, half-maximal inhibitory concentration: "not active" (no number reported)
Compound 4: no number reported; no gap can be computed for the estimate.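

For the compounds shown here, compound 4 is reported in this assay only as "not active", with no number, so no step from compound 3 to compound 4 can be read. The compounds shown leave open how far compound 4 lies from compound 3, and whether it compares with the limit held by compound 1: the limit of > 100000 nM in this assay, at which 1 of the 4 values shown sits.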